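The compounds below may be only part of what the source reports. "The series", "measured", "known", "first", "only" and "open" are said of these compounds alone.

Compound 1 `CC(CNCC1CC1)Oc1cccc2ccc(N)nc12` is the starting point. Going by the values given here, in a functional assay on IMR-32 cells with melanin-concentrating hormone receptor 1 (Homo sapiens) as the target, read by fluorescence (on this read-out lower numbers stand for stronger inhibition and higher numbers for weaker inhibition), compound 1 gives 460 nM, the higher of the two numbers measured so far. Its nearest neighbour is compound 2 `CC(CN1CCCC1)Oc1cccc2ccc(N)nc12`, which differs only in the group on the amine; in this assay compound 2 gives 360 nM, and the step of a 1.3-fold lower number from compound 1 to compound 2 (0.11 log units; within the scatter) lies within the scatter. The new compound, compound 3 `COc1cccc(CNCC(C)Oc2cccc3ccc(N)nc23)c1`, keeps the shared core and the chain but changes the substituent on the amine nitrogen: 3-methoxyphenyl in place of cyclopropyl on a saturated chain carbon bound to an amine nitrogen. Among the compounds with values here, no measured step touches this kind of change; the only measured step, between compound 1 and compound 2, concerns the amine itself and was within the scatter, so it gives no direction for the exchange of cyclopropyl for 3-methoxyphenyl. With nothing to lean on beyond compound 1 itself, the expectation for compound 3 in this assay is a number close to its parent, estimated at 300 nM with a range from 80 nM to 1200 nM. The expected step is therefore a 1.5-fold lower number from compound 1 to compound 3 (0.19 log units; within the scatter), not clearly beyond the scatter.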

Compound 3, half-maximal inhibitory concentration: 600 nM
Estimate against measurement, compound 3: 2.0-fold (0.30 log units) below; measured number inside the range.
By their numbers in this assay, from the lowest: compounds 2, 1 and 3 (each within the scatter of the next).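

In this assay, the exchange of cyclopropyl for 3-methoxyphenyl on a saturated chain carbon bound to an amine nitrogen gives a 1.3-fold higher number from compound 1 to compound 3 (0.12 log units; within the scatter), so this place accepts a group of 8 heavy atoms in place of one of 3, with a six-membered aromatic ring and a hydrogen-bond acceptor entering, without a step beyond the scatter. This is the first reading at this place, and like the change at the amine, a 1.3-fold lower number from compound 1 to compound 2 (0.11 log units; within the scatter), it leaves the number without a clear shift, so neither change shown so far gives a direction. No measured evidence on the properties of these groups bears on this result.

The aromatic ring and the methoxy group enter together here, so a plain phenyl group would be needed to tell them apart, and nothing shown says whether the methoxy group counts for anything at this place. As far as these compounds go, it also stays open whether a different kind of group at this place, such as a carboxylic acid or an amine, or a longer chain, would carry the number beyond the scatter in either direction.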